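Cytotoxicity series on hamster kidney cells: step to compound 4

A few compounds are considered here, and "the series" means these few. Any claim that something is new, unique, unknown or untested is made for them only; others in the source may bear on it.

Measured compounds:
compound 1 `CC(Sc1nnc(-c2ccncc2)s1)C(=O)NCc1ccccc1` in an ADME assay on BHK-21 cells (Mesocricetus auratus) for cytotoxicity, with a stated time of 3 days (a higher number here means that more compound is tolerated, a lower number that less compound is tolerated), gives > 50000 nM, which is a limit of the assay.
compound 2 `O=C(CCSc1nnc(-c2ccncc2)s1)Nc1ccc(Cl)cc1Cl` in this assay gives > 50000 nM, which is a limit of the assay.
compound 3 `O=C(CSc1nnc(-c2ccncc2)s1)Nc1ccccc1Cl` in this assay gives > 50000 nM, which is a limit of the assay.

Compound 2 stands, like the other two, at the limit (the limit of > 50000 nM in this assay, at which 3 of the 3 values shown sit); no number is known for it, only that the assay reports nothing below that limit. For the measured compounds named here, no step between two measured compounds can be computed, since all three values are limits.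

The unmeasured compound 4 `O=C(CCSc1nnc(-c2ccncc2)s1)NCc1ccc(Cl)cc1` differs from compound 2 by 4-chlorobenzyl in place of 2,4-dichlorophenyl on an amide-type nitrogen.

Given that every measured member of the series sits at the limit (the limit of > 50000 nM in this assay, at which 3 of the 3 values shown sit), no step beyond the scatter is expected in this assay in either direction, and the step from compound 2 to compound 4 is estimated as a number no higher from compound 2 to compound 4 (the limit leaves the size open). For compound 4 the expected value in this assay is 50000 nM, with a range from 20000 nM to 150000 nM, and most likely again only a limit.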

Compound 4, half-maximal cytotoxic concentration: 21500 nM
The estimate for compound 4 lay 2.3-fold (0.37 log units) above the measured number; low and high end bracket the measured number.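

In this assay, for the compounds shown here, compound 4 gives 21500 nM, the first actual number rather than a limit. Going by these compounds alone, on the amide-type nitrogen, 4-chlorobenzyl in place of 2,4-dichlorophenyl gives an at least 2.3-fold lower number from compound 2 to compound 4 (0.36 log units; beyond the scatter), so the group at this position can affect the number read in this assay, which the earlier compounds could not show. The size of the step remains open at one end, since the value of compound 2 is a limit, as are most values in the series: the limit of > 50000 nM in this assay, at which 3 of the 4 values shown sit.

4-chlorobenzyl differs from 2,4-dichlorophenyl in both its carbon and its chlorine count, and the compounds shown do not separate these two differences. Also open, as far as these compounds go, is how an amine, a carboxylic acid or a longer chain in place of 4-chlorobenzyl on the amide-type nitrogen would read in this assay.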